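Working notes: hydroxy for diethylamino, compound 1 to compound 3

A few compounds are considered here, and "the series" means these few. Any claim that something is new, unique, unknown or untested is made for them only; others in the source may bear on it.

Measured so far:
compound 1 `CCN(CC)c1ccc(/C=C/C(=O)c2ccc(OC)c3c2OC(C)(C)C=C3)cc1` — 550 nM
compound 2 `COc1ccc(C(=O)/C=C/c2ccc(OC)c(OC)c2OC)c2c1C=CC(C)(C)O2` — a limit, see below

In a functional assay on HT-29 cells (Homo sapiens) for antiproliferative activity, read by MTT assay, with a stated time of 24 h (a lower number here means a stronger inhibitor, a higher number a weaker inhibitor), compound 1 gives 550 nM. Compound 2 returns only a limit of this assay, > 10000 nM. Within the data shown here, compound 1 therefore stands as the only numerical value in this assay; the other result is the limit of > 10000 nM in this assay, at which 1 of the 2 values shown sits. Among the measured compounds shown here, no pair of measured compounds differs in a single place, so no measured step is at hand, and the two structures that are measured cannot be compared beyond what their two values show.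

Compound 3 `COc1ccc(C(=O)/C=C/c2ccc(O)cc2)c2c1C=CC(C)(C)O2` is the next compound for this assay. It differs from compound 1 by hydroxy in place of diethylamino on an aromatic carbon.

For the measured compounds named here, with no measured step to lean on, the size and direction of this change rest on the structural change alone. A loss of potency beyond the usual scatter is expected in this assay, of moderate size, though a result outside the measurable range cannot be excluded. Compound 3 is estimated at 3000 nM, with a range of 800 nM to 15000 nM. The expected step is a 5.5-fold higher number from compound 1 to compound 3 (0.74 log units; beyond the scatter).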

Compound 3, half-maximal inhibitory concentration: > 10000 nM
Compound 3 gave a limit, no number; the forecaster's own chance of this, stated with the estimate: 30%; middle value at least 3.3-fold (0.52 log units) away from the limit.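

Among these compounds, this is the first single-place step: in this assay, hydroxy in place of diethylamino on an aromatic carbon, para to a large group, gives an at least 18-fold higher number from compound 1 to compound 3 (1.25 log units; beyond the scatter). The value of compound 3, > 10000 nM, is a limit of the assay and not a number. On the shared core, a measurable value at this position is thus seen with diethylamino and lost with hydroxy, and compound 3 joins the upper end of the readable range: the limit of > 10000 nM in this assay, at which 2 of the 3 values shown sit.

The change removes the nitrogen and the four carbons of diethylamino together, so this one step cannot show which part of the group the value of compound 1 depends on; a dimethylamino or a plain amino group on the same aromatic carbon would begin to separate the two. Going by these compounds, how far compound 3 lies past its limit also stays open, as does whether any other group at this position matches or improves on diethylamino in this assay.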